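The source may report more compounds than this note shows. Statements on the series, on what has been measured and on what is new or still open speak of the compounds shown alone.

Measured in a functional assay on PC-3 cells (Homo sapiens) for cytotoxicity, read by WST assay, with a stated time of 72 h; on this read-out lower numbers stand for stronger inhibition and higher numbers for weaker inhibition (lower numbers mean stronger inhibition):

Compound 1 `Cc1ccc(C2(c3ccc(O)cc3)C(=O)Nc3c2ccc(F)c3F)cc1` gives 0.8 nM as a true number
Compound 2 `CCCOc1ccc(C2(c3ccc(O)cc3)C(=O)Nc3c2ccc(F)c3F)cc1` gives > 1000 nM as a limit
Compound 3 `CCCCCOc1ccc(C2(c3ccc(O)cc3)C(=O)Nc3c2ccc(F)c3F)cc1` gives > 1000 nM as a limit

Within the data shown here, compound 1 holds the only true number here, and the other two results are limits. Compound 4 `O=C1Nc2c(ccc(F)c2F)C1(c1ccc(O)cc1)c1cccnc1` keeps the core of compound 1 but carries pyridin-3-yl in place of 4-methylphenyl on a saturated ring carbon. The nearest evidence is two large steps at the methyl of compound 1, an at least 1200-fold higher number from compound 1 to compound 2 (3.09 log units; beyond the scatter) and an at least 1200-fold higher number from compound 1 to compound 3 (3.09 log units; beyond the scatter), which show that this group tolerates change poorly. Compound 4 also loses that methyl, so a clear rise is expected, though probably a smaller one. The expected change is a 25-fold higher number from compound 1 to compound 4 (1.40 log units; beyond the scatter) (an estimate). For compound 4 the estimated value is 20 nM (expected range 1.5 nM to 300 nM).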

Compound 4, half-maximal inhibitory concentration: > 1000 nM
Compound 4 ended at the assay's limit (the forecaster's own chance of this, stated with the estimate: 15%); at least 50-fold (1.69 log units) between middle value and limit.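

The earlier steps shown here only changed the methyl of compound 1, while this one replaces the whole 4-methylphenyl with pyridin-3-yl on the saturated ring carbon, giving an at least 1200-fold higher number from compound 1 to compound 4 (3.09 log units; beyond the scatter). So a step this large does not need a longer chain on that ring: swapping in pyridin-3-yl, which has a ring nitrogen and no methyl, is enough. Steps between two limits cannot be read, and this step gives only a minimum size: the limit of > 1000 nM in this assay, at which 3 of the 4 values shown sit.

Going by these compounds, what stays open is whether losing the methyl or gaining the ring nitrogen matters more. A plain phenyl or a 4-ethylphenyl at this position would help separate the two.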